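A few compounds are considered here, and "the series" means these few. Any claim that something is new, unique, unknown or untested is made for them only; others in the source may bear on it.

Three compounds have been measured in a functional assay on CHO-K1 cells for antagonist activity at transient receptor potential cation channel subfamily V member 1 (Homo sapiens), read by FLIPR; a lower number here means a stronger inhibitor, a higher number a weaker inhibitor:

compound 1, `Cc1ccc(Cl)cc1Nc1nc(C(F)(F)F)ccc1CNC(=O)C(C)c1ccc(NS(C)(=O)=O)c(F)c1`, 140 nM
compound 2, `C[C@@H](C(=O)NCc1ccc(C(F)(F)F)nc1N1CCC(c2ccccc2)CC1)c1ccc(NS(C)(=O)=O)c(F)c1`, 2350 nM
compound 3, `CC(C(=O)NCc1ccc(C(F)(F)F)nc1N1CCC(Cc2ccc(F)c(F)c2)CC1)c1ccc(NS(C)(=O)=O)c(F)c1`, 30 nM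

Among these three, compound 1 stands second highest: compound 3 gives a lower number, beyond the scatter, and compound 2 a far higher one, also beyond the scatter. Compound 4, `CC(C(=O)NCc1ccc(C(F)(F)F)nc1N1CCCCCC1)c1ccc(NS(C)(=O)=O)c(F)c1`, has not yet been measured. It differs from compound 1 in one place: azepan-1-yl in place of (5-chloro-2-methylphenyl)amino on an aromatic carbon. Among the compounds with values here, no pair of measured compounds differs in just one place, so nothing directly shows how much this change matters. The group that leaves carries an aromatic ring and a hydrogen-bond donor, and the azepan-1-yl group that enters has neither, so a step towards a higher number, beyond the scatter, is expected. The estimated step is an 11-fold higher number from compound 1 to compound 4 (1.03 log units; beyond the scatter). Compound 4 is expected to give about 1500 nM, between 300 nM and 8000 nM.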

Compound 4, half-maximal inhibitory concentration: 25.1 nM
Beside the measured number, compound 4's estimate is 60-fold (1.78 log units) above it, and the stated range ends above it.
By their numbers in this assay, from the lowest: compounds 4 and 3 (each within the scatter of the next); then compound 1; then compound 2.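

Putting azepan-1-yl in place of (5-chloro-2-methylphenyl)amino, on the aromatic carbon next to the ring nitrogen, gives a 5.6-fold lower number from compound 1 to compound 4 (0.75 log units; beyond the scatter) in this assay. So a low number at this position requires neither an aromatic ring nor a hydrogen-bond donor in the group attached there. Nothing available explains why this change lowers the number.

The compounds shown leave open how the result depends on the ring itself. Unsubstituted pyrrolidin-1-yl, piperidin-1-yl or morpholin-4-yl at this position would test that.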